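Trimethoxyphenyl triazoles: a methoxyphenyl variant awaits measurement

This account rests on a few compounds, and the source may have more. Where it says the series, first, only, none or still open, it means among the compounds named here.

Measured compounds:
compound 1 `COc1cc(-n2ncnc2-c2cccc([N+](=O)[O-])c2)cc(OC)c1OC`: > 10000 nM
compound 2 `COc1cc(-c2ncnn2-c2cccc(N)c2)cc(OC)c1OC`: > 10000 nM

In a functional assay on A549 cells (Homo sapiens) for antiproliferative activity, read by MTT assay, with a stated time of 72 h (on this read-out higher numbers stand for weaker inhibition and lower numbers for stronger inhibition), compound 1 reached only a limit of the assay, > 10000 nM. In this assay compound 2 likewise reached only a limit, > 10000 nM. Compound 2 therefore stands where both shown values stand, at the limit of > 10000 nM in this assay, at which 2 of the 2 values shown sit, and no numbered value is available for it.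

Compound 3 `COc1ccc(-n2ncnc2-c2cc(OC)c(OC)c(OC)c2)cc1` differs from compound 2 by 4-methoxyphenyl in place of 3-aminophenyl on an aromatic nitrogen. Going by the values given here, no step between two measured compounds is available for comparison, so the size of this change in this assay rests on expectation alone; a limit gives no firm point from which to measure movement in either direction.

Compound 3 is expected to give about 5000 nM in this assay, within a range of 800 nM to 30000 nM. The step this means, an at least 2.0-fold lower number from compound 2 to compound 3 (0.30 log units; that floor lies within the scatter), is an estimate only.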

Compound 3, half-maximal inhibitory concentration: > 10000 nM
Compound 3 gave a limit, no number (the forecaster's own chance of this, stated with the estimate: 45%); at least 2.0-fold (0.30 log units) between middle value and limit.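

In this assay compound 3 gives > 10000 nM, a limit and not a number. No step can be read from compound 2 to compound 3, since both stop at a limit: the limit of > 10000 nM in this assay, at which 3 of the 3 values shown sit.

The compounds shown leave open which change to the shared core, if any, would give a numbered value.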